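Taking the nitro group off compound 1

The source may report more compounds than this note shows. Statements on the series, on what has been measured and on what is new or still open speak of the compounds shown alone.

Of the compounds shown here, two have numbers so far in a functional assay on MRC5 cells (Homo sapiens) for cytotoxicity, read by colorimetric assay and MTT assay; on this read-out lower numbers stand for higher toxicity in this test and higher numbers for lower toxicity in this test. Compound 1 `CCN(CC)c1ccc(/C=N/NC(=O)c2ccc([N+](=O)[O-])cc2)c(O)c1` gives 2500 nM, the lower of the two, and compound 2 `CC(C)(C)c1ccc(O)c(/C=N/NC(=O)c2cccs2)c1` gives 12000 nM. The gap between them lies beyond the usual scatter, so compound 1 is the more toxic of the pair in this assay. The two differ in more than one place, however, so this gap cannot be tied to any single group.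

Compound 3 `CCN(CC)c1ccc(/C=N/NC(=O)c2ccccc2)c(O)c1` keeps the core of compound 1, with hydrogen in place of nitro on an aromatic carbon, para to a large group (hydrogen in place of nitro on an aromatic carbon). Within the data shown here, no measured pair isolates a single change, so the size of this step has no direct precedent. Compound 2, which also carries no nitro, stands at 12000 nM, but that offers only weak support. A modest move toward a higher number is expected, and a result within the scatter of compound 1 would not be surprising. The expected change is a 2.0-fold higher number from compound 1 to compound 3 (0.30 log units; within the scatter). For compound 3 the estimated value is 5000 nM, with an expected range from 1800 nM to 14000 nM.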

Compound 3, half-maximal cytotoxic concentration: 1100 nM
Compound 3: the middle estimate sits 4.5-fold (0.66 log units) above what was measured; the measured number lies below the stated range.
By their numbers in this assay, from the lowest: compound 3; then compound 1; then compound 2.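

In this assay, the series now has its first step that changes a single place: a 2.3-fold lower number from compound 1 to compound 3 (0.36 log units; beyond the scatter), with hydrogen in place of nitro on an aromatic carbon, para to a large group. The step is modest but beyond the scatter, and it shows that nitro at this position on the core of compound 1 is not required for toxicity in this test, since the compound with hydrogen there has the lower number and so the higher toxicity in this test. Nothing at hand accounts for the direction of this step.

A single pair cannot show whether the shift belongs to nitro in particular or would follow the loss of any group at this position, and an amine, a carboxylic acid or a chlorine atom on the same carbon would help separate those readings. From the compounds shown here alone, whether the same replacement moves the number the same way on any other core also stays open, as this step rests on the core of compound 1 alone.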